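A chloro for fluoro swap at the assay limit

A few compounds are considered here, and "the series" means these few. Any claim that something is new, unique, unknown or untested is made for them only; others in the source may bear on it.

Measured in a functional assay on HepG2 cells (Homo sapiens) for cytotoxicity, with a stated time of 72 h (a lower number here means that less compound is needed, a higher number that more compound is needed for the effect), with each value a limit:
Compound 1 `C=C[C@@](C)(/C=C/c1ccc(Nc2ccc(Cl)cc2)cc1)CCC=C(C)C` gives > 52000 nM as a limit
Compound 2 `C=C[C@@](C)(/C=C/c1ccc(-c2ccccc2)cc1)CCC=C(C)C` gives > 52000 nM as a limit
Compound 3 `C=C[C@@](C)(/C=C/c1ccc(-c2ccc(F)cc2)cc1)CCC=C(C)C` gives > 52000 nM as a limit

Compound 3 stands at > 52000 nM in this assay as a limit and not a number. All the series offers is the limit of > 52000 nM in this assay, at which 3 of the 3 values shown sit, and no number. Compound 4 `C=C[C@@](C)(/C=C/c1ccc(-c2ccc(Cl)cc2)cc1)CCC=C(C)C` differs from compound 3 by one change chloro in place of fluoro on an aromatic carbon in words chloro in place of fluoro on an aromatic carbon, para to a large group. The closest measured change, fluoro in place of hydrogen on an aromatic carbon, is a step that the two limits leave unreadable from compound 2 to compound 3 and the others are a step that the two limits leave unreadable from compound 1 to compound 2 and a step that the two limits leave unreadable from compound 1 to compound 3 so none gives a size. No step beyond the scatter, in either direction, is therefore expected in this assay for this change. In numbers, the expected step is a number no higher from compound 3 to compound 4 (the limit leaves the size open) in size. For compound 4 the estimate is 52000 nM with an expected range of 30000 nM to 80000 nM in this read-out.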

Compound 4, half-maximal effective concentration: > 52000 nM
Compound 4: only a limit was reported (the forecaster's own chance of this, stated with the estimate: 80%); the middle value lies on the limit itself.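

Compound 4, like compound 1, compound 2 and compound 3, sits at a limit and not a number in this assay, so no step among them can be read: the limit of > 52000 nM in this assay, at which 4 of the 4 values shown sit.

The compounds shown leave open what concentration, if any, gives the half-maximal effect for any of them, and so whether chloro and fluoro differ here at all.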